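This account rests on a few compounds, and the source may have more. Where it says the series, first, only, none or still open, it means among the compounds named here.

Working notes on the series. Compound 1 is `Cc1cc(Cl)c(S(C)(=O)=O)cc1C(=O)N=C(N)N`, compound 2 is `Cc1cc(Br)c(S(C)(=O)=O)cc1C(=O)N=C(N)N` and compound 3 is `CS(=O)(=O)c1cc(C(=O)N=C(N)N)c(Cl)cc1Cl`. In a functional assay for inhibition of sodium/hydrogen exchanger (Oryctolagus cuniculus) (a higher number here means a weaker inhibitor, a lower number a stronger inhibitor), compound 1 gives 25 nM, compound 2 gives 12 nM and compound 3 gives 140 nM. Compound 1 therefore stands second highest of the three numbers, closest to compound 2 and furthest from compound 3. The two single-point steps measured so far are a 2.1-fold lower number from compound 1 to compound 2 (0.32 log units; beyond the scatter) and a 5.6-fold higher number from compound 1 to compound 3 (0.75 log units; beyond the scatter); both replace one substituent with another on the ring.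

The next compound, compound 4, is `Cc1c(C(=O)N=C(N)N)cc(S(C)(=O)=O)c(Cl)c1[N+](=O)[O-]`. Relative to compound 1 the change is nitro in place of hydrogen on an aromatic carbon. Within the data shown here, neither measured step bears on this change directly: no compound so far carries a nitro group, and neither step adds a group where a hydrogen stood. The expectation is therefore weak. Given that the substituent changes seen to date moved this assay only modestly in either direction, a modest shift is expected for compound 4, and an estimate of 35 nM is taken, with a range of 10 nM to 120 nM. That estimate corresponds to an expected step of a 1.4-fold higher number from compound 1 to compound 4 (0.15 log units; within the scatter).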

Compound 4, half-maximal inhibitory concentration: 44 nM
Compound 4: the middle estimate sits 1.3-fold (0.10 log units) below what was measured; the range from low to high includes it.
By their numbers in this assay, from the lowest: compound 2; then compounds 1 and 4 (each within the scatter of the next); then compound 3.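

Among these compounds, the earlier compounds only exchanged one ring substituent for another, whereas compound 4 is the first to place a group on a ring carbon that carries hydrogen in compound 1, ortho to a chloro group and ortho to a methyl group. In this assay nitro at this place gives a 1.8-fold higher number from compound 1 to compound 4 (0.25 log units; within the scatter), so this ring hydrogen can be replaced by a group of three heavy atoms without a step beyond the scatter. Nothing measured here bears on why nitro at this place leaves the number within the scatter of compound 1.

Going by these compounds, whether this place accepts other groups in the same way stays open, for example an amine, a carboxylic acid or a longer chain such as propyl. Also open, on these data alone, is whether nitro at this place would give a comparable step with bromo in place of chloro, as in compound 2.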